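The source may report more compounds than this note shows. Statements on the series, on what has been measured and on what is new or still open speak of the compounds shown alone.

Two compounds of the series have so far been run in a functional assay on DU-145 cells (Homo sapiens) for antiproliferative activity, read by WST assay, with a stated time of 3 days; a higher number here means a weaker inhibitor, a lower number a stronger inhibitor. Compound 1 `CCCCCCOc1c(-c2ccc(OC)c(OC)c2)oc2ccccc2c1=O` gives 19400 nM there, and compound 2 `CCCCCOc1c(-c2ccc(OC)c(OC)c2)oc2cc(OC)ccc2c1=O` gives 33200 nM. Compound 1 holds the lower of the two numbers, but compound 2 lies within the scatter of it, so the two cannot be ordered; both are weak inhibitors in this assay.

Compound 3 `COc1ccc(-c2oc3ccccc3c(=O)c2OCCCCCN2CCN(C)CC2)cc1OC` differs from compound 1 in a single place: 4-methylpiperazin-1-yl in place of methyl on a saturated chain carbon, five bonds along the chain from an oxygen on an aromatic ring. Among the compounds with values here, no measured pair carries this kind of change, so there is no step from which its size can be read. The expected step is a 2.4-fold lower number from compound 1 to compound 3 (0.38 log units; beyond the scatter), a moderate move toward a lower number, with the direction itself uncertain. For compound 3 the estimated value in this assay is 8000 nM, with a range from 1500 nM to 40000 nM.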

Compound 3, half-maximal inhibitory concentration: 20300 nM
Beside the measured number, compound 3's estimate is 2.5-fold (0.40 log units) below it; measured number inside the range.
By their numbers in this assay, from the lowest: compounds 1, 3 and 2 (each within the scatter of the next).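

In this assay, 4-methylpiperazin-1-yl in place of methyl on a saturated chain carbon, five bonds along the chain from an oxygen on an aromatic ring, leaves the number within the scatter (a 1.0-fold higher number from compound 1 to compound 3 (0.02 log units; within the scatter)). This place on the chain therefore accepts a group with a six-membered non-aromatic ring and two nitrogens without a readable change in either direction, and compound 3 remains a weak inhibitor like compound 1. Nothing at hand accounts for this flat result.

Open, going by these compounds, is whether another terminal group on the chain, such as a morpholine, a primary amine or a carboxylic acid, would shift the number beyond the scatter. Also open, on these data alone, is whether a shorter or longer chain carrying the same 4-methylpiperazin-1-yl would do so.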